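Trimming a Sulfonamide: Cyclopentyl to Ethyl

This account rests on a few compounds, and the source may have more. Where it says the series, first, only, none or still open, it means among the compounds named here.

Compound 3 `CCN(C1CCCC1)S(=O)(=O)c1ccc(NC(=O)NCc2ccncc2)cc1` gives 60 nM in an assay on isolated protein for activation of Nicotinamide phosphoribosyltransferase (Homo sapiens) (a higher number here means that more compound is needed for the effect, a lower number that less compound is needed), the second highest of the three numbers measured. Compound 1 `CN(Cc1ccccc1)S(=O)(=O)c1ccc(NC(=O)NCc2ccncc2)cc1` gives 23 nM, and the step of a 2.6-fold higher number from compound 1 to compound 3 (0.42 log units; beyond the scatter) shows what one change at the sulfonamide group did. Compound 2 `O=C(NCc1ccncc1)Nc1ccc(S(=O)(=O)N2CCc3ccccc3C2)cc1` gives 142 nM, and the step of a 2.4-fold lower number from compound 2 to compound 3 (0.37 log units; beyond the scatter) runs the other way. Compound 4 `CCN(CC)S(=O)(=O)c1ccc(NC(=O)NCc2ccncc2)cc1` differs from compound 3 by ethyl in place of cyclopentyl on a sulfonamide nitrogen. Both measured steps alter the group on the same sulfonamide nitrogen and are modest in size, so a change of similar size is expected here, although neither step tests an ethyl against a cyclopentyl directly. Compound 4 is therefore expected to give 100 nM, within 35 nM to 300 nM, an estimated step of a 1.7-fold higher number from compound 3 to compound 4 (0.22 log units; within the scatter) leaning toward a higher number.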

Compound 4, half-maximal effective concentration: 384 nM
Compound 4: the middle estimate sits 3.8-fold (0.58 log units) below what was measured, and the stated range ends below it.
By their numbers in this assay, from the lowest: compound 1; then compound 3; then compound 2; then compound 4.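

Losing the cyclopentyl ring on this sulfonamide nitrogen costs far more than the earlier changes suggested, with ethyl in its place giving a 6.4-fold higher number from compound 3 to compound 4 (0.81 log units; beyond the scatter). In this assay, among the compounds shown here, the diethylamino group also falls behind both other groups on the sulfonyl sulfur, with a 2.7-fold higher number from compound 2 to compound 4 (0.43 log units; beyond the scatter) and a 17-fold higher number from compound 1 to compound 4 (1.22 log units; beyond the scatter), the latter the only large step so far; yet size alone does not set the order, as compound 2 carries a ring and still needs more compound than compound 3. Nothing measured here gives a reason for these steps.

As far as these compounds go, whether a cyclopropyl or a propyl in place of the ethyl would recover any of the loss remains open.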